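The source may report more compounds than this note shows. Statements on the series, on what has been measured and on what is new or still open speak of the compounds shown alone.

Compound 1 `CC1CC/C(=N\Nc2ccc([N+](=O)[O-])cc2)c2ncc(C(=O)O)c(=O)n21` gives > 320 umol/kg in a functional assay on the whole organism for inhibition, with Rattus norvegicus as the target (on this read-out higher numbers stand for an effect only at larger amounts of compound and lower numbers for an effect already at smaller amounts), a limit of the assay rather than a number.
Compound 2 `CC(=O)c1ccc(N/N=C2\CCC(C)n3c2ncc(C(=O)O)c3=O)cc1` gives > 100 umol/kg in this assay, again a limit.
Compound 3 `CCc1ccc(N/N=C2\CCC(C)n3c2ncc(C(=O)O)c3=O)cc1` gives > 1000 umol/kg in this assay, also a limit.

Compound 3 thus stands at a limit, and the two other values shown are limits as well (the limit of > 1000 umol/kg in this assay, at which 1 of the 3 values shown sits). The measured steps, a step that the two limits leave unreadable from compound 1 to compound 2, a step that the two limits leave unreadable from compound 1 to compound 3 and a step that the two limits leave unreadable from compound 2 to compound 3, all concern the substituent on the aromatic carbon and all remain unreadable between their limits, so none of them gives a readable size for any change. Within the data shown here, compound 4 `CC1CC/C(=N\Nc2ccc(CC(=O)O)cc2)c2ncc(C(=O)O)c(=O)n21` differs from compound 3 by carboxy in place of methyl on a saturated chain carbon bound to an aromatic carbon, a change at a different place from the measured ones, on which no measured step bears. With compound 3 at a limit and no readable step in the series, the expectation rests only on the shared core and the limits shown. Compound 4 is therefore expected to sit near 1000 umol/kg, within 200 umol/kg to 5000 umol/kg, and this corresponds to an expected step of a number no higher from compound 3 to compound 4 (the limit leaves the size open), most likely reported again as a limit.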

Compound 4, dose for 50% inhibition: > 100 umol/kg
Compound 4: a limit, no number; the forecaster's own chance of this, stated with the estimate: 80%; the middle value lies beyond the limit too.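

The steps joining compound 4 to compound 1, compound 2 and compound 3 cannot be read, as all four compounds stand at limits in this assay. The compounds shown leave open whether any of these substituents gives a numerical value, and how they would rank.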